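Replacing the oxolanyl carbamate of compound 3 with a fluorinated cyclopentyl amide

The compounds below may be only part of what the source reports. "The series", "measured", "known", "first", "only" and "open" are said of these compounds alone.

Compound 3 `CS(=O)(=O)c1cnc(O[C@H]2CC[C@H](OC3CCN(C(=O)OC4CCOC4)CC3)CC2)cn1` shows the highest number of the three measured compounds in a functional assay on isolated protein for agonist activity at Glucose-dependent insulinotropic receptor (Homo sapiens), read by HTRF and cAMP accumulation (a lower number here means that less compound is needed, a higher number that more compound is needed for the effect), giving 427 nM. Compound 1 `CC1(OC(=O)N2CCC(O[C@H]3CC[C@H](Oc4cnc(S(C)(=O)=O)cn4)CC3)CC2)CC1` gives 25.9 nM in this assay, and compound 2 `C[C@H](CF)OC(=O)N1CCC(O[C@H]2CC[C@H](Oc3cnc(S(C)(=O)=O)cn3)CC2)CC1` gives 36.8 nM. The steps to compound 3 are both large: a 16-fold higher number from compound 1 to compound 3 (1.22 log units; beyond the scatter) and a 12-fold higher number from compound 2 to compound 3 (1.06 log units; beyond the scatter), whereas a 1.4-fold higher number from compound 1 to compound 2 (0.15 log units; within the scatter). Compound 4 `CS(=O)(=O)c1cnc(O[C@H]2CC[C@H](OC3CCN(C(=O)C4(C(F)(F)F)CCCC4)CC3)CC2)cn1` differs from compound 3 in that (a group of 9 heavy atoms (6 carbon, 3 fluorine; one five-membered non-aromatic ring of carbon only) in place of a group of 6 heavy atoms (4 carbon, 2 oxygen; one five-membered non-aromatic ring with 1 hetero atom), on a carbonyl carbon); with the oxygen gone, the carbonyl now carries a carbon ring directly. Among the compounds with values here, no measured step removes that oxygen, so only the pattern that oxolan-3-yl goes with much higher numbers than the carbon-based groups of compound 1 and compound 2 bears on it. Since compound 4 again carries a ring of carbon only, a clearly lower number than compound 3 is expected, roughly a 7.1-fold lower number from compound 3 to compound 4 (0.85 log units; beyond the scatter), though the unknown effect of losing the oxygen widens the range. Compound 4 is therefore estimated at 60 nM, between 15 nM and 250 nM.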

Compound 4, half-maximal effective concentration: 38.4 nM
Compound 4: the middle estimate sits 1.6-fold (0.19 log units) above what was measured; measured number inside the range.
By their numbers in this assay, from the lowest: compounds 1, 2 and 4 (each within the scatter of the next); then compound 3.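

In this assay, an 11-fold lower number from compound 3 to compound 4 (1.05 log units; beyond the scatter), and compound 4 is the first compound shown in which the carbonyl carries a carbon ring directly, so the oxygen on that carbonyl carbon is not needed for a low number. a 1.0-fold higher number from compound 2 to compound 4 (0.02 log units; within the scatter) and a 1.5-fold higher number from compound 1 to compound 4 (0.17 log units; within the scatter), both within the scatter, so a group of this larger size, with a five-membered ring of carbon only, reads alike with the groups of compound 1 and compound 2, leaving compound 3 alone apart from the other three. Nothing available explains why the oxolan-3-yl group of compound 3 stands apart.

From the compounds shown here alone, the step to compound 4 changes the ring and removes the oxygen together, so their separate shares stay open. Going by these compounds, it also remains open how a cyclopentyl amide without the trifluoromethyl group, or a cyclopentyl carbamate, would read.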